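Ortho-methoxy on the phenyl of compound 1

A few compounds are considered here, and "the series" means these few. Any claim that something is new, unique, unknown or untested is made for them only; others in the source may bear on it.

Measured compounds:
compound 1 `c1ccc(-c2cn3ccnc3c(-c3ccc4ncn(C5CCCCC5)c4c3)n2)cc1` — 37.3%
compound 2 `Fc1ccc(-c2cn3ccnc3c(-c3ccc4ncn(C5CCCCC5)c4c3)n2)cc1` — 7.94%
compound 3 `Clc1ccc(-c2cn3ccnc3c(-c3ccc4ncn(C5CCCCC5)c4c3)n2)cc1` — 11.3%

In a functional assay on U-251 cells (Homo sapiens) for inhibition, read by sulforhodamine B assay, with a stated time of 48 h, tested at 10 uM (a lower number here means less inhibition, a higher number more inhibition at the concentration tested (going by the name of the read-out)), compound 1 gives the highest of the three numbers, 37.3%. The two compounds that differ from it in one place both fall below it: a number 29.4 percentage points lower from compound 1 to compound 2 (beyond the scatter) and a number 26 percentage points lower from compound 1 to compound 3 (beyond the scatter), each beyond the scatter. Between the two halogen compounds the gap is small: a number 3.4 percentage points higher from compound 2 to compound 3 (within the scatter), within the scatter.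

Compound 4 `COc1ccccc1-c1cn2ccnc2c(-c2ccc3ncn(C4CCCCC4)c3c2)n1` is not yet measured. Its change from compound 1 is methoxy in place of hydrogen on an aromatic carbon. Going by the values given here, no measured step puts a methoxy onto this ring, and no measured step touches this particular position; the two steps from compound 1 concern fluoro and chloro at another place on the same ring. What they show is that each substituent added to the unsubstituted phenyl of compound 1 lowered the read-out by a modest amount. On that basis a drop is expected for compound 4 too, though with wide uncertainty because the group and its place both differ from anything measured.

The step expected is a number 17.3 percentage points lower from compound 1 to compound 4 (beyond the scatter). Compound 4 is estimated at 20%, with a range from 5% to 40%.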

Compound 4, a percentage reported as inhibition, at one concentration (the size of the read-out at that concentration, not a potency): 21%
Compound 4: the middle estimate sits 1 percentage points below what was measured; the range from low to high includes it.
By their numbers in this assay, from the lowest: compounds 2, 3 and 4 (each within the scatter of the next, the first and the last beyond it); then compound 1.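

In this assay, methoxy on an aromatic carbon, ortho to a large group, gives a number 16.3 percentage points lower from compound 1 to compound 4 (beyond the scatter), so the loss seen on the phenyl of compound 1 is not confined to fluoro and chloro or to the place they occupy, and compound 1 stays beyond the scatter of all three substituted compounds. The 2-methoxyphenyl group is separated from 4-fluorophenyl, with a number 13.1 percentage points higher from compound 2 to compound 4 (beyond the scatter), but not from 4-chlorophenyl, with a number 9.7 percentage points higher from compound 3 to compound 4 (within the scatter), so the step from compound 3 gives no order between those two compounds, and the three substituted compounds do not form three distinct levels in this read-out. No supporting measurement bears on why methoxy at this position has this effect.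

The compounds shown do not separate the effect of the group from that of its place, as methoxy and the halogens never share a position here, so the two cannot be compared at a single place on the ring. On these data alone, how an amine or a carboxylic acid on this phenyl would read in this assay also remains open, as does whether any substituent on this ring can match or exceed compound 1.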